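The compounds below may be only part of what the source reports. "The series", "measured", "known", "first", "only" and "open" are said of these compounds alone.

Working notes on a set of four amides that share one side of the molecule and differ in the core and in a single halogen. Compound 1 `O=C(Nc1ccc(Oc2ccncc2-c2cccnc2)c(F)c1)c1nn(-c2ccc(F)cc2)c(=O)c2ccccc12` carries a 4-fluorophenyl on its core; in a functional assay on A549 cells (Homo sapiens) for cytotoxicity, read by MTT assay, with a stated time of 72 h (a lower number here means a stronger inhibitor, a higher number a weaker inhibitor), compound 1 gives 820 nM. Compound 2 `O=C(Nc1ccc(Oc2ccncc2-c2cccnc2)c(F)c1)c1nn(-c2ccc(Cl)cc2)c(=O)c2ccccc12` is its chloro counterpart, and in this assay compound 2 gives 1020 nM. The change between them is fluoro in place of chloro on an aromatic carbon, and the step it makes is a 1.2-fold lower number from compound 2 to compound 1 (0.09 log units; within the scatter), so the two are not told apart here.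

Compound 3 `O=C(Nc1ccc(Oc2ccncc2-c2cccnc2)c(F)c1)c1ccnn(-c2ccc(Cl)cc2)c1=O` is built on a different core with the 4-chlorophenyl retained; in this assay compound 3 gives 6560 nM, the highest number of the three. The difference between the two cores is not broken down here; the values show that compound 3 sits beyond the scatter from both compound 2 and compound 1.

Compound 4 `O=C(Nc1ccc(Oc2ccncc2-c2cccnc2)c(F)c1)c1ccnn(-c2ccc(F)cc2)c1=O` is not yet measured. Relative to compound 3 it has fluoro in place of chloro on an aromatic carbon, the same change, at the same place, that turns compound 2 into compound 1. Because a 1.2-fold lower number from compound 2 to compound 1 (0.09 log units; within the scatter) lay within the scatter, the expected step is a 1.2-fold lower number from compound 3 to compound 4 (0.08 log units; within the scatter), essentially flat. That expectation rests on a single pair, and nothing shows whether the core of compound 3 answers the halogen swap any differently. Compound 4 is therefore expected to come in near 5500 nM in this assay, with a likely span of 2500 nM to 12000 nM.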

Compound 4, half-maximal inhibitory concentration: 2880 nM
Compound 4: the middle estimate sits 1.9-fold (0.28 log units) above what was measured, and the stated range covers the measured number.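

In this assay, the swap from 4-chlorophenyl to 4-fluorophenyl gives a 2.3-fold lower number from compound 3 to compound 4 (0.36 log units; beyond the scatter), a modest step that lies beyond the scatter when taken alone, while on the other core the same swap gives a 1.2-fold lower number from compound 2 to compound 1 (0.09 log units; within the scatter). Set side by side, the two steps cannot be told apart, so the halogen swap can be read as carrying from one core to the other without a detectable difference: the same change on two cores in this assay, a 1.2-fold lower number (0.09 log units; within the scatter) from compound 2 to compound 1 and a 2.3-fold lower number (0.36 log units; beyond the scatter) from compound 3 to compound 4, 1.8-fold (0.26 log units) apart, within the scatter of two such steps. This does not show that the swap has the same size on both cores, as two pairs in a single cell assay cannot exclude a modest dependence on the core, and it gives no reason for either step.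

The compounds shown leave open how a methoxy group, a nitrile or an amine would read in this assay in place of the halogen on the aromatic carbon, and so whether the small steps seen here are particular to fluoro and chloro. Also open, going by these compounds, is whether the swap would behave in the same way on a third core, or with a different group on the far side of the amide.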